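From Fluoro to Methoxy on the Shared Core

The source may hold more compounds than are shown below. What is called first, only, known or untested is meant among the compounds shown, and "the series" means these compounds.

In an assay on isolated protein for inhibition of Rho-associated protein kinase 1 (Homo sapiens), read by scintillation counting, radiometric assay and 33P incorporation, with a stated time of 40 min, in the presence of a further agent that is not named here (a lower number here means a stronger inhibitor, a higher number a weaker inhibitor), compound 3 `O=C(COc1ccc2c(=O)ccoc2c1)Nc1cccc(NC(=O)c2ccc(F)cc2)c1` gives 129 nM. Compound 2 `CCCc1ccc(C(=O)Nc2cccc(NC(=O)COc3ccc4c(=O)ccoc4c3)c2)cc1` gives 143 nM and compound 1 `CCc1ccc(C(=O)Nc2cccc(NC(=O)COc3ccc4c(=O)ccoc4c3)c2)cc1` gives 235 nM in this assay, and compound 3 stands within the scatter of both, as the steps of a 1.8-fold lower number from compound 1 to compound 3 (0.26 log units; within the scatter) and a 1.1-fold lower number from compound 2 to compound 3 (0.04 log units; within the scatter) show; the step of a 1.6-fold lower number from compound 1 to compound 2 (0.22 log units; within the scatter) is likewise small. Compound 4 `COc1ccc(C(=O)Nc2cccc(NC(=O)COc3ccc4c(=O)ccoc4c3)c2)cc1` differs from compound 3 by methoxy in place of fluoro on an aromatic carbon. All three measured steps exchange groups on this same aromatic carbon, and none moved the number beyond the scatter, so a further exchange there is expected to leave the number about where it is. Compound 4 is therefore estimated at 160 nM in this assay, with a range from 70 nM to 350 nM, an expected step of a 1.2-fold higher number from compound 3 to compound 4 (0.09 log units; within the scatter).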

Compound 4, half-maximal inhibitory concentration: 18 nM
The estimate for compound 4 lay 8.9-fold (0.95 log units) above the measured number; measured number outside the range, below it.
By their numbers in this assay, from the lowest: compound 4; then compounds 3, 2 and 1 (each within the scatter of the next).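

Methoxy is the first group on this aromatic carbon to move the number beyond the scatter: a 7.2-fold lower number from compound 3 to compound 4 (0.86 log units; beyond the scatter), a 7.9-fold lower number from compound 2 to compound 4 (0.90 log units; beyond the scatter) and a 13-fold lower number from compound 1 to compound 4 (1.12 log units; beyond the scatter). The position therefore does respond to its substituent in this assay, although fluoro, ethyl and propyl gave no sign of this. No measurement shown here explains the gain. Going by these compounds, it remains open whether the oxygen alone or the whole methoxy group matters, which a hydroxy or an ethoxy group on this carbon could help separate.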